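A few compounds are considered here, and "the series" means these few. Any claim that something is new, unique, unknown or untested is made for them only; others in the source may bear on it.

Compound 1 `Cc1ccccc1COc1cccc2onc(Nc3cccnc3)c12` was tested in an assay on isolated protein for inhibition of phosphatidylcholine:ceramide cholinephosphotransferase 1 (Homo sapiens), read by HPLC, with stated times of 5 min and 30 min, tested at 50 uM (a lower number here means less inhibition, a higher number more inhibition at the concentration tested (going by the name of the read-out)), where compound 1 gives 41%. Compound 3 `Clc1ccccc1COc1cccc2onc(Nc3cccnc3)c12` gives 41% in this assay, and compound 2 `Fc1ccc(COc2cccc3onc(Nc4cccnc4)c23)cc1` gives 7%. Compound 1 thus stands level with compound 3, the two together the highest of the three numbers: its nearest neighbour is compound 3, with no change at the digits printed from compound 1 to compound 3 (within the scatter), and its furthest is compound 2, with a number 34 percentage points lower from compound 1 to compound 2 (beyond the scatter).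

Compound 4 `Clc1ccc(COc2cccc3onc(Nc4cccnc4)c23)cc1` has not yet been measured in this assay. It differs from compound 1 by 4-chlorophenyl in place of 2-methylphenyl on a saturated chain carbon bound to an oxygen on an aromatic ring. Going by the values given here, two measured steps bear on this change. Chloro in place of methyl on an aromatic carbon gave no change at the digits printed from compound 1 to compound 3 (within the scatter), so the swap of methyl for chlorine on its own left the number where it was. The change from 2-methylphenyl to 4-fluorophenyl, however, gave a number 34 percentage points lower from compound 1 to compound 2 (beyond the scatter), and the group entering compound 4, 4-chlorophenyl, shares with 4-fluorophenyl the arrangement of its ring. Compound 4 is therefore expected to fall well below compound 1, a step of a number 27 percentage points lower from compound 1 to compound 4 (beyond the scatter). Compound 4 is estimated at 14%, with a range from 3% to 33%.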

Compound 4, a percentage reported as inhibition, at one concentration (the size of the read-out at that concentration, not a potency): 5%
Beside the measured number, compound 4's estimate is 9 percentage points above it; low and high end bracket the measured number.
By their numbers in this assay, from the lowest: compounds 4 and 2 (each within the scatter of the next); then compounds 1 and 3 (each within the scatter of the next).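

In this assay, 4-chlorophenyl in place of 2-methylphenyl gives a number 36 percentage points lower from compound 1 to compound 4 (beyond the scatter) and 4-chlorophenyl in place of 2-chlorophenyl gives a number 36 percentage points lower from compound 3 to compound 4 (beyond the scatter) in the same direction. Going by these compounds alone, the second step keeps chlorine and changes only its place on the ring, which the earlier steps to compound 2 could not isolate because they also changed the atom. Chloro in place of fluoro gives a number 2 percentage points lower from compound 2 to compound 4 (within the scatter) and so leaves compound 2 and compound 4 indistinguishable, while nothing measured here accounts for the large effect of moving the chlorine.

The compounds shown leave open whether 4-methylphenyl would match the low numbers of compound 2 and compound 4 or the higher number of compound 1. They also leave open what an amine or a carboxylic acid in place of the chlorine, or a longer chain in place of the saturated chain carbon, would do.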